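From Hydroxy to Methoxymethyl on a Saturated Ring

A few compounds are considered here, and "the series" means these few. Any claim that something is new, unique, unknown or untested is made for them only; others in the source may bear on it.

Of the compounds shown here, three have so far been measured in a physicochemical assay for solubility, in phosphate buffer, at pH 7.4; on this read-out higher numbers stand for higher solubility and lower numbers for lower solubility. Compound 1 (`OCC1CCN(c2nccnc2Oc2ccc(Nc3nc4ccccc4s3)cc2)CC1`) gives 6000 nM. Compound 2 (`OCC1CCN(c2nccnc2OC2CN(c3ncc4ccccc4n3)C2)CC1`) gives 174000 nM. Among the compounds with values here, compound 3 (`OC1CCN(c2nccnc2OC2CN(c3ccc4ccccc4n3)C2)CC1`) gives 99000 nM, a number within the usual scatter of the one for compound 2 and well beyond the scatter above the one for compound 1.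

The next compound to be measured is compound 4 (`COCC1CCN(c2nccnc2OC2CN(c3ccc4ccccc4n3)C2)CC1`). It differs from compound 3 by methoxymethyl in place of hydroxy on a saturated ring carbon. Within the data shown here, no two measured compounds differ in one place only, so the data offer no direct measure of this change, and any forecast is tentative.

A step down in this assay is expected, modestly beyond the scatter. Compound 1, at 6000 nM, is the lowest of the measured numbers, and compound 4 is expected to stay clear above it. The estimated move is a 2.5-fold lower number from compound 3 to compound 4 (0.39 log units; beyond the scatter). For compound 4 the estimate is 40000 nM, with an expected range from 12000 nM to 110000 nM.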

Compound 4, solubility: 53000 nM
The estimate for compound 4 lay 1.3-fold (0.12 log units) below the measured number, and the stated range covers the measured number.
By their numbers in this assay, from the lowest: compound 1; then compounds 4, 3 and 2 (each within the scatter of the next, the first and the last beyond it).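

In this assay, within the data shown here, this pair gives the first direct reading of a single change, and the change is a 1.9-fold lower number from compound 3 to compound 4 (0.27 log units; within the scatter) when methoxymethyl takes the place of hydroxy on a saturated ring carbon, three ring bonds from the ring nitrogen. The step is within the scatter, so on this core 4-hydroxypiperidin-1-yl and 4-(methoxymethyl)piperidin-1-yl cannot be told apart on this read-out, even though the exchange replaces a group with 1 hydrogen-bond donor by one with 0 hydrogen-bond donors and 3 heavy atoms. The information at hand offers no measured basis for explaining this result.

A single pair cannot show whether the same exchange would read alike on the core of compound 1 or the core of compound 2. It also leaves open how an amine, a carboxylic acid or a longer ether chain on this ring carbon would compare with hydroxy and methoxymethyl on the core shared by compound 3 and compound 4.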